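The source may report more compounds than this note shows. Statements on the series, on what has been measured and on what is new or still open speak of the compounds shown alone.

Measured so far:
compound 1, `OC[C@H]1O[C@@H](n2cnc3c(NCc4ccccc4F)ncnc32)[C@H](O)[C@@H]1O`, gives 33200 nM;
compound 2, `COc1ccccc1CNc1ncnc2c1ncn2[C@@H]1O[C@H](CO)[C@@H](O)[C@H]1O`, gives 89000 nM;
compound 3, `OC[C@H]1O[C@@H](n2cnc3c(NCc4ccc(Cl)cc4Cl)ncnc32)[C@H](O)[C@@H]1O`, gives 106000 nM.

All three share one core and differ only in the substituted phenyl ring on the saturated chain carbon bound to a nitrogen on the aromatic ring. In a functional assay on K562 cells (Homo sapiens) for antiproliferative activity, with a stated time of 72 h (a higher number here means a weaker inhibitor, a lower number a stronger inhibitor), compound 3 gives the highest of the three numbers; its nearest neighbour is compound 2, and the gap between them, a 1.2-fold higher number from compound 2 to compound 3 (0.08 log units; within the scatter), is within the scatter, while the gap from compound 1, a 3.2-fold higher number from compound 1 to compound 3 (0.50 log units; beyond the scatter), is beyond it.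

Compound 4, `OC[C@H]1O[C@@H](n2cnc3c(NCc4ccc(F)c(Cl)c4)ncnc32)[C@H](O)[C@@H]1O`, is not yet measured. It differs from compound 3 in one place: 3-chloro-4-fluorophenyl in place of 2,4-dichlorophenyl on a saturated chain carbon bound to a nitrogen on an aromatic ring.

Going by the values given here, the steps that bear on this are the two earlier swaps of the phenyl ring at the same place. From compound 1 to compound 3 the number rose, a 3.2-fold higher number from compound 1 to compound 3 (0.50 log units; beyond the scatter); from compound 2 to compound 3 it hardly moved, a 1.2-fold higher number from compound 2 to compound 3 (0.08 log units; within the scatter). Both are small. Since compound 1, the one carrying a fluoro, has the lowest number, a modest fall from compound 3 toward compound 1 is expected, a 1.8-fold lower number from compound 3 to compound 4 (0.25 log units; within the scatter). Compound 4 is therefore estimated at 60000 nM, with a range from 25000 nM to 150000 nM.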

Compound 4, half-maximal inhibitory concentration: 5500 nM
Compound 4: the middle estimate sits 11-fold (1.04 log units) above what was measured, and the stated range ends above it.
By their numbers in this assay, from the lowest: compound 4; then compound 1; then compounds 2 and 3 (each within the scatter of the next).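

In this assay, this place on the saturated chain carbon proves far more sensitive than the first three compounds suggested, with a 19-fold lower number from compound 3 to compound 4 (1.28 log units; beyond the scatter) and a 16-fold lower number from compound 2 to compound 4 (1.21 log units; beyond the scatter) as the two largest steps shown. Even against the 2-fluorophenyl ring of compound 1, the previous best, there is a 6.0-fold lower number from compound 1 to compound 4 (0.78 log units; beyond the scatter) and compound 4 is the strongest of the four, while 2,4-dichlorophenyl and 3-chloro-4-fluorophenyl have the same heavy-atom count and neither has hydrogen-bond donors or acceptors, so those counts do not separate them. Nothing available here explains why the new ring does so much better.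

From the compounds shown here alone, it remains open whether the chlorine, the fluoro or the combination carries the gain, which a plain phenyl or a ring with only one of these halogens could help to separate. Also open, going by these compounds, is whether a longer chain to the ring, or an amine or carboxylic acid on it, would keep the gain.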